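A few compounds are considered here, and "the series" means these few. Any claim that something is new, unique, unknown or untested is made for them only; others in the source may bear on it.

In a functional assay on L02 cells (Homo sapiens) for inhibition (a higher number here means a weaker inhibitor, a lower number a stronger inhibitor), compound 1 (`CCN(C(=O)CC(CC(=O)NCCN1CCCC1)c1ccc(Cl)cc1)C1Cc2ccccc2C1`) gives 54200 nM. Compound 2 (`CCNCCNC(=O)CC(CC(=O)N(CC)C1Cc2ccccc2C1)c1ccccc1`) reads > 100000 nM, which is a limit of the assay and not a number. Compound 3 (`CCN(C(=O)CC(CC(=O)NCCN1CCCC1)c1ccccc1)C1Cc2ccccc2C1`) differs from compound 2 in one place, on a saturated chain carbon, two bonds along the chain from an amide-type nitrogen: pyrrolidin-1-yl in place of ethylamino on a saturated chain carbon, two bonds along the chain from an amide-type nitrogen. Among the measured compounds shown here, a small move toward stronger inhibition in this assay is expected because compound 1 reads 54200 nM, although no measured step supports this. The estimated change is an at least 1.1-fold lower number from compound 2 to compound 3 (0.07 log units; that floor lies within the scatter), which may not exceed the scatter. Compound 3 is expected at 85000 nM, with an estimated range of 42000 nM to 170000 nM.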

Compound 3, half-maximal inhibitory concentration: > 100000 nM
Compound 3 ended at the assay's limit; the forecaster's own chance of this, stated with the estimate: 45%; middle value at least 1.1-fold (0.07 log units) from the limit.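

In this assay compound 3 reads > 100000 nM, which is a limit of the assay and not a number. Hydrogen in place of chloro on an aromatic carbon gives an at least 1.8-fold higher number from compound 1 to compound 3 (0.26 log units; that floor lies within the scatter), so the chloro group is tied to the only value below the limit, although the floor of that step does not clear the scatter. The change from ethylamino to pyrrolidin-1-yl cannot be read, since compound 2 and compound 3 both end at the limit: the limit of > 100000 nM in this assay, at which 2 of the 3 values shown sit.

Open, as far as these compounds go, is whether fluoro or methoxy on that aromatic carbon would give a readable value. Also open, from the compounds shown here alone, is how piperidin-1-yl would read in place of pyrrolidin-1-yl with the chloro group kept.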